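The source may hold more compounds than are shown below. What is called first, only, known or untested is meant among the compounds shown, and "the series" means these compounds.

In a functional assay on the whole organism (strain Wistar) for inhibition, with Rattus norvegicus as the target, read by paw edema, with stated times of 60 min and 6 h, at a dose of 100 mg/kg by the oral route (a lower number here means less inhibition, a higher number more inhibition at the dose given (going by the name of the read-out)), compound 1 `CNC(=O)CC1CCc2cc(OC)c(OC)cc21` gives 24.1%, compound 2 `COc1cc2c(cc1OC)C(CC(=O)N(C)C)CC2` gives 33.3%, and compound 3 `COc1cc2c(cc1OC)C(CC(=O)NC(C)C)CC2` gives 37%, the highest of the three numbers, although its gap to compound 2 lies within the scatter. Compound 4 `COc1cc2c(cc1OC)C(CC(=O)NC(C)(C)C)CC2` differs from compound 3 by methyl in place of hydrogen on a saturated chain carbon bound to an amide-type nitrogen and two saturated chain carbons. The earlier changes at the amide-type nitrogen bear on this: the step of a number 9.2 percentage points higher from compound 1 to compound 2 (within the scatter) and the step of a number 3.7 percentage points higher from compound 2 to compound 3 (within the scatter) were both small, while the step of a number 12.9 percentage points higher from compound 1 to compound 3 (beyond the scatter) was the only one beyond the scatter, and modest. Another small change is therefore expected, with a step of a number 3 percentage points higher from compound 3 to compound 4 (within the scatter) that stays within the scatter. Compound 4 is estimated at 40%, with a range of 28% to 52%.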

Compound 4, a percentage reported as inhibition, in the whole organism at one dose (the size of the read-out at that dose, not a potency): 31.5%
For compound 4 the middle estimate is 8.5 percentage points above the measured one; low and high end bracket the measured number.
By their numbers in this assay, from the lowest: compounds 1, 4, 2 and 3 (each within the scatter of the next, the first and the last beyond it).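

In this assay the added methyl gives a number 5.5 percentage points lower from compound 3 to compound 4 (within the scatter) and so does not separate the tert-butyl amide from the isopropyl amide. Within the data shown here, the (tert-butyl)amino group gives a number 1.8 percentage points lower from compound 2 to compound 4 (within the scatter) against dimethylamino, and tert-butyl gives a number 7.4 percentage points higher from compound 1 to compound 4 (within the scatter) against methyl, so a larger group on this nitrogen does not by itself go with a step beyond the scatter, and compound 3 remains the only one apart from compound 1. No evidence here bears on these steps. What the compounds shown leave open is whether a cyclohexyl or benzyl group on this nitrogen, or a carboxylic acid in place of the amide, would move the number beyond the scatter.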